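The source may report more compounds than this note shows. Statements on the series, on what has been measured and on what is new or still open speak of the compounds shown alone.

Compounds measured so far: compound 1 `Cc1cccc(/C(N)=N/NC(=S)N2CCSCC2)n1` gives 62.6%; compound 2 `N/C(=N\NC(=S)N1CCCCC1)c1ccccn1` gives 85.8%; compound 3 `Cc1cccc(/C(N)=N/NC(=S)N2CCOCC2)n1` gives 43.6%, all in a functional assay on A-375 cells (Homo sapiens) for cytotoxicity, read by MTT assay, with a stated time of 72 h, tested at 10 uM; on this read-out higher numbers stand for more inhibition of growth at the one concentration tested and lower numbers for less inhibition of growth.

Compound 3 stands lowest of the three numbers. Going by the values given here, the one step that bears directly on it is the exchange from compound 1 to compound 3, which brought a number 19 percentage points lower from compound 1 to compound 3 (beyond the scatter). Compound 4 `Cc1cccc(/C(N)=N/NC(=S)N2CCCCC2)n1` carries piperidin-1-yl in place of morpholin-4-yl on a thiocarbonyl carbon. Compound 2, which also carries piperidin-1-yl on its thiocarbonyl carbon but on a core without the methyl group, shows the highest number of the set. Taken together, a rise beyond the scatter is expected for compound 4 in this assay, estimated at a number 24.4 percentage points higher from compound 3 to compound 4 (beyond the scatter), giving an expected value of 68% with a range from 50% to 86%.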

Compound 4, percent growth inhibition at one concentration: 76.4%
Compound 4: middle estimate off by 8.4 percentage points, on the low side; measured number inside the range.
By their numbers in this assay, from the lowest: compound 3; then compound 1; then compounds 4 and 2 (each within the scatter of the next).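

In this assay the ring on the thiocarbonyl carbon decides much of the number on this core: piperidin-1-yl in place of morpholin-4-yl brought a number 32.8 percentage points higher from compound 3 to compound 4 (beyond the scatter) and piperidin-1-yl in place of thiomorpholin-4-yl brought a number 13.8 percentage points higher from compound 1 to compound 4 (beyond the scatter) so the three rings now fall in a clear order. Methyl in place of hydrogen on an aromatic carbon brought a number 9.4 percentage points lower from compound 2 to compound 4 (within the scatter) and so the high number of compound 2 does not depend on the missing methyl. Nothing available explains these differences.

On these data alone, whether a piperazin-1-yl ring or an open-chain diethylamino group on the thiocarbonyl carbon would match piperidin-1-yl remains open.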